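The source may report more compounds than this note shows. Statements on the series, on what has been measured and on what is new or still open speak of the compounds shown alone.

Measured compounds:
compound 1, `CCOC(=O)COc1ccc2c(=O)c(-c3ccc(O)cc3)coc2c1`, in an assay (Cricetulus griseus) for inhibition of aldehyde dehydrogenase, mitochondrial (Homo sapiens) (on this read-out lower numbers stand for stronger inhibition and higher numbers for weaker inhibition), compound 1 gives 130 nM.
compound 2, `O=C(O)CCCCCOc1ccc2c(=O)cc(-c3ccc(O)cc3)oc2c1`, in this assay compound 2 gives 3500 nM.

Among the measured compounds shown here, compound 1 holds the lowest of the two numbers; compound 2 lies far above it, well beyond the scatter, and no single-point step connects the two. Compound 3, `C=CCOc1ccc2c(=O)c(-c3ccc(O)cc3)coc2c1`, is derived from compound 1 by the change (vinyl in place of ethoxycarbonyl on a saturated chain carbon bound to an oxygen on an aromatic ring). For the measured compounds named here, no measured pair shows this change, so its effect is unknown. Compound 3 is expected to lose a little potency, a step of a 1.9-fold higher number from compound 1 to compound 3 (0.28 log units; within the scatter) that is modest and may fall within the scatter. For compound 3 the estimated value is 250 nM, between 80 nM and 800 nM.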

Compound 3, half-maximal inhibitory concentration: 180 nM
Compound 3: middle estimate off by 1.4-fold (0.14 log units), on the high side; the measured number falls inside the stated range.
By their numbers in this assay, from the lowest: compounds 1 and 3 (each within the scatter of the next); then compound 2.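

In this assay the swap of ethoxycarbonyl for vinyl on a saturated chain carbon bound to an oxygen on an aromatic ring gives a 1.4-fold higher number from compound 1 to compound 3 (0.14 log units; within the scatter) and so leaves the read-out unchanged within the scatter. At this place the ester is thus not required: the entering group has no hydrogen-bond acceptors against the two of the group that leaves, and the number holds. No evidence at hand explains this.

As far as these compounds go, whether an amine or an amide at this place would hold the number as well remains open. So does whether a saturated propyl chain would match the allyl group.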